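Isobutoxy in place of 2-phenylethenyl: expected effect

The compounds below may be only part of what the source reports. "The series", "measured", "known", "first", "only" and "open" are said of these compounds alone.

In a functional assay on COLO 205 cells (Homo sapiens) for antiproliferative activity (on this read-out higher numbers stand for weaker inhibition and lower numbers for stronger inhibition), compound 2 (`O=C(/C=C/c1ccccc1)N[C@@H](CCCCCC(=O)NO)C(=O)Nc1cccc2cccnc12`) gives 141 nM. This lies within the scatter of compound 3 (`O=C(CCCCC[C@H](NC(=O)OCc1ccccc1)C(=O)Nc1cccc2cccnc12)NO`) at 122 nM and of compound 1 (`O=C(CCCCC[C@H](NC(=O)c1ccc(Br)cc1)C(=O)Nc1ccc(-c2ccccc2)cc1)NO`) at 272 nM, so the three numbers offer no clear ranking around compound 2.

Compound 4 (`CC(C)COC(=O)N[C@@H](CCCCCC(=O)NO)C(=O)Nc1cccc2cccnc12`) follows from compound 2 by one change: isobutoxy in place of 2-phenylethenyl on a carbonyl carbon. Isobutoxy thus stands in place of 2-phenylethenyl on a carbonyl carbon.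

Within the data shown here, one measured step bears on this change: a 1.2-fold lower number from compound 2 to compound 3 (0.06 log units; within the scatter), with benzyloxy in place of 2-phenylethenyl on the same carbonyl carbon. Among the measured compounds shown here, no measured compound has a group without a ring on that carbonyl carbon, so this single step is only a partial guide and the range stays wide.

A change beyond the scatter in this assay is therefore not expected, and no direction is predicted. The estimated step is a 1.1-fold higher number from compound 2 to compound 4 (0.03 log units; within the scatter). For compound 4 the expected value is 150 nM, with an estimated range of 70 nM to 320 nM.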

Compound 4, half-maximal inhibitory concentration: 395 nM
Compound 4: middle estimate off by 2.6-fold (0.42 log units), on the low side; the measured number lies above the stated range.
By their numbers in this assay, from the lowest: compounds 3, 2, 1 and 4 (each within the scatter of the next, the first and the last beyond it).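

In this assay the group on this carbonyl carbon now matters: isobutoxy in place of 2-phenylethenyl gives a 2.8-fold higher number from compound 2 to compound 4 (0.45 log units; beyond the scatter), and the comparison with the benzyloxy group gives a 3.2-fold higher number from compound 3 to compound 4 (0.51 log units; beyond the scatter). Compound 2 and compound 3, both with a six-membered aromatic ring in this group, lie within the scatter of each other, while compound 4, with no ring there, stands apart from both, and none of these three goes against that split. No measurement at hand accounts for this shift.

Still open, from the compounds shown here alone, is whether the ring itself or the size of the group decides the number, which a cyclohexylmethoxy group or a longer straight chain such as hexyloxy on the same carbonyl carbon would separate. Also open, going by these compounds, is how an amine at this place would read.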